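A Piperidine Swap in a Receptor Antagonist Series

A few compounds are considered here, and "the series" means these few. Any claim that something is new, unique, unknown or untested is made for them only; others in the source may bear on it.

In an assay on blood for antagonist activity at prostaglandin E2 receptor EP4 subtype (Homo sapiens), read by immunoassay, with stated times of 30 min and 24 h (on this read-out lower numbers stand for stronger inhibition and higher numbers for weaker inhibition), compound 2 `Cc1ccc(N2CCC(F)(F)CC2)nc1C(=O)Nc1c(C)cc(C(=O)O)cc1C` gives 1160 nM, the lower of the two numbers in hand, though compound 1 `Cc1ccc(N2CCCC(CO)C2)nc1C(=O)Nc1c(C)cc(C(=O)O)cc1C` gives 1450 nM and the step of a 1.3-fold lower number from compound 1 to compound 2 (0.10 log units; within the scatter) lies within the scatter. Compound 3 `Cc1ccc(N2CCC(C)(O)CC2)nc1C(=O)Nc1c(C)cc(C(=O)O)cc1C` differs from compound 2 by 4-hydroxy-4-methylpiperidin-1-yl in place of 4,4-difluoropiperidin-1-yl on an aromatic carbon. Within the data shown here, the only measured step that bears on this change, a 1.3-fold lower number from compound 1 to compound 2 (0.10 log units; within the scatter), also exchanged one piperidine substituent for another and stayed within the scatter, so no step beyond the scatter is expected in either direction. Compound 3 is therefore expected to give 1300 nM, between 600 nM and 2800 nM. The expected step is a 1.1-fold higher number from compound 2 to compound 3 (0.05 log units; within the scatter).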

Compound 3, half-maximal inhibitory concentration: 3600 nM
Estimate against measurement, compound 3: 2.8-fold (0.44 log units) below; the measured number lies above the stated range.
By their numbers in this assay, from the lowest: compounds 2 and 1 (each within the scatter of the next); then compound 3.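

Unlike the earlier swap, the piperidine exchange at this position now moves the number beyond the scatter in this assay: 4-hydroxy-4-methylpiperidin-1-yl in place of 4,4-difluoropiperidin-1-yl gives a 3.1-fold higher number from compound 2 to compound 3 (0.49 log units; beyond the scatter), and in place of 3-(hydroxymethyl)piperidin-1-yl it gives a 2.5-fold higher number from compound 1 to compound 3 (0.39 log units; beyond the scatter). Compound 1 also carries a hydroxyl yet stays within the scatter of compound 2, so the presence of a hydroxyl alone does not set the number. Nothing in the data gives a reason for these steps.

The compounds do not separate the hydroxyl from the methyl within 4-hydroxy-4-methylpiperidin-1-yl. From the compounds shown here alone, it also remains open whether a morpholine or an unsubstituted piperidine here would stand with compound 2 or with compound 3.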